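The source may hold more compounds than are shown below. What is called first, only, known or untested is meant among the compounds shown, and "the series" means these compounds.

Measured so far in a functional assay on HOP-92 cells (Homo sapiens) for inhibition, read by sulforhodamine B assay, with a stated time of 48 h; a higher number here means a weaker inhibitor, a lower number a stronger inhibitor:
compound 1 `COc1cc(-c2nn(-c3cccc(NC(=O)c4cccc(C(F)(F)F)c4)c3)cc2-c2ccncc2)ccc1Cl`, 560 nM
compound 2 `COc1cc(-c2nn(-c3cccc(NC(=O)c4ccc(Cl)c(C(F)(F)F)c4)c3)cc2-c2ccncc2)ccc1Cl`, 670 nM

Compound 2 stands at the higher of the two numbers, yet its step from compound 1, a 1.2-fold higher number from compound 1 to compound 2 (0.08 log units; within the scatter), lies within the scatter. Compound 3 `COc1cc(-c2nn(-c3cccc(NC(=O)Nc4ccc(Cl)c(C(F)(F)F)c4)c3)cc2-c2ccncc2)ccc1Cl` differs from compound 2 by (4-chloro-3-(trifluoromethyl)phenyl)amino in place of 4-chloro-3-(trifluoromethyl)phenyl on a carbonyl carbon. Within the data shown here, no measured step alters this part of the molecule; the only step available, a 1.2-fold higher number from compound 1 to compound 2 (0.08 log units; within the scatter), concerns an aromatic substituent instead, so it gives little guidance. With nothing pointing either way, a change in this assay of no more than the scatter is expected. Compound 3 is expected to give 550 nM, between 200 nM and 1500 nM. The expected step is a 1.2-fold lower number from compound 2 to compound 3 (0.09 log units; within the scatter).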

Compound 3, half-maximal inhibitory concentration: 500 nM
Compound 3: the middle estimate sits 1.1-fold (0.04 log units) above what was measured, and the stated range covers the measured number.
By their numbers in this assay, from the lowest: compounds 3, 1 and 2 (each within the scatter of the next).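

In this assay, putting (4-chloro-3-(trifluoromethyl)phenyl)amino on the carbonyl carbon in place of 4-chloro-3-(trifluoromethyl)phenyl leaves the number within the scatter (a 1.3-fold lower number from compound 2 to compound 3 (0.13 log units; within the scatter)), so this exchange at this position makes no clear difference here. The comparison with the unchlorinated compound agrees (a 1.1-fold lower number from compound 1 to compound 3 (0.05 log units; within the scatter)). No measurement shown explains why the numbers stay so close. Still open, going by these compounds, is whether a different group on the carbonyl carbon, such as a simple alkyl chain or a cyclohexylamino group, would shift the number beyond the scatter.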